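Aryl amine variation on the pyridone amide series

The source may report more compounds than this note shows. Statements on the series, on what has been measured and on what is new or still open speak of the compounds shown alone.

Measured compounds:
Compound 1 `COc1cc2c(Oc3ccc(NC(=O)c4nn(-c5ccccc5)c(=O)cc4C)cc3F)ccnc2cc1OCCCN1CCCCC1` — 160 nM
Compound 2 `COc1cc2c(Oc3ccc(NC(=O)c4nn(-c5ccccc5OC(F)(F)F)c(=O)cc4C)cc3F)ccnc2cc1OCCCN1CCCC1` — 180 nM
Compound 3 `COc1cc2c(Oc3ccc(NC(=O)c4nn(-c5ccccc5OC(F)(F)F)c(=O)cc4C)cc3F)ccnc2cc1OCCCN1CCCCC1` — 190 nM

All three numbers come from a functional assay on HT-29 cells (Homo sapiens) for inhibition, read by MTT assay, with a stated time of 72 h; on this read-out higher numbers stand for weaker inhibition and lower numbers for stronger inhibition. Compound 3 carries the highest of the three numbers, but the gaps to its neighbours are small: the step of a 1.1-fold higher number from compound 2 to compound 3 (0.02 log units; within the scatter) and the step of a 1.2-fold higher number from compound 1 to compound 3 (0.07 log units; within the scatter) both sit within the scatter, so the three compounds cannot be ordered against one another on this read-out.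

Compound 4 `COc1cc2c(Oc3ccc(NC(=O)c4nn(-c5cccc(F)c5)c(=O)cc4C)cc3F)ccnc2cc1OCCCN1CCCCC1` is not yet measured. It differs from compound 3 in one place: 3-fluorophenyl in place of 2-(trifluoromethoxy)phenyl on an aromatic nitrogen. Among the compounds with values here, the only measured step that touches the same phenyl ring is the one from compound 1 to compound 3, in which trifluoromethoxy replaced hydrogen on an aromatic carbon and the number moved by a 1.2-fold higher number from compound 1 to compound 3 (0.07 log units; within the scatter). Within the data shown here, no measured pair speaks to a fluorine on that ring, nor to removing the trifluoromethoxy again; the change from compound 3 to compound 4 is therefore only partly covered by what has been measured.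

Given that the one relevant step stayed within the scatter, no shift beyond the scatter is expected for compound 4, and the step of a 1.1-fold lower number from compound 3 to compound 4 (0.05 log units; within the scatter) is estimated to be small. Compound 4 is expected to give about 170 nM in this assay, with a range from 80 nM to 360 nM.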

Compound 4, half-maximal inhibitory concentration: 290 nM
Compound 4: the middle estimate sits 1.7-fold (0.23 log units) below what was measured, and the stated range covers the measured number.
By their numbers in this assay, from the lowest: compounds 1, 2, 3 and 4 (each within the scatter of the next).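

In this assay, 3-fluorophenyl in place of 2-(trifluoromethoxy)phenyl on the aromatic nitrogen gives a 1.5-fold higher number from compound 3 to compound 4 (0.18 log units; within the scatter), so a group of fewer heavy atoms yields no step beyond the scatter on this read-out. Read against the plain phenyl group, fluoro in place of hydrogen on an aromatic carbon gives a 1.8-fold higher number from compound 1 to compound 4 (0.26 log units; within the scatter), the first reading of a substituent on this ring other than trifluoromethoxy, and this step also stays within the scatter. No independent measurement is available to account for these numbers.

The compounds shown leave open whether the result for the fluoro group depends on where it sits on the phenyl ring, and whether a substituent of another kind on that ring, such as a nitrile, a primary amine or a carboxylic acid, would produce a step beyond the scatter. From the compounds shown here alone, it also remains open whether the 3-fluorophenyl group would read the same alongside pyrrolidin-1-yl, or alongside a morpholine in place of piperidin-1-yl.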